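The source may hold more compounds than are shown below. What is called first, only, known or untested is meant among the compounds shown, and "the series" means these compounds.

Measured compounds:
Compound 1 `CCOC(=O)c1c(-c2cccc(-c3ccccc3)c2)[nH]c2cc(Cl)c(Cl)cc2c1=O` — in an ADME assay on HEK293 cells (Homo sapiens) for cytotoxicity, read by luminescence, with a stated time of 72 h (on this read-out higher numbers stand for an effect only at larger amounts of compound and lower numbers for an effect already at smaller amounts), compound 1 gives > 22000 nM, a limit of the assay.
Compound 2 `CCOC(=O)c1c(-c2cccc(OC)c2)[nH]c2cc(Cl)c(Cl)cc2c1=O` — in this assay compound 2 gives > 22000 nM, a limit of the assay.
Compound 3 `CCOC(=O)c1c(-c2cccc(-c3ccccc3)c2)[nH]c2cc(OC)c(F)cc2c1=O` — in this assay compound 3 gives > 22000 nM, a limit of the assay.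

Compound 2 differs from compound 1 by methoxy in place of phenyl on an aromatic carbon. The step that the two limits leave unreadable from compound 1 to compound 2 cannot be sized because of the limit of > 22000 nM in this assay, at which 3 of the 3 values shown sit. Compound 3 carries a different core; the difference between the two cores is not broken down here. Compound 4 `CCOC(=O)c1c(-c2cccc(OC)c2)[nH]c2cc(OC)c(F)cc2c1=O` has not yet been measured in this assay; it differs from compound 3 by methoxy in place of phenyl on an aromatic carbon, the same change as from compound 1 to compound 2. Since compound 1, compound 2 and compound 3 all sit at the limit (the limit of > 22000 nM in this assay, at which 3 of the 3 values shown sit), compound 4 is expected to sit there as well, with an estimated step that the limit leaves unreadable from compound 3 to compound 4. In this assay compound 4 is expected to give 30000 nM, estimated between 15000 nM and 100000 nM.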

Compound 4, half-maximal effective concentration: > 22000 nM
Compound 4: only a limit was reported; the forecaster's own chance of this, stated with the estimate: 85%; the middle value does not contradict the limit.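

No step can be read from compound 3 to compound 4, because both values are limits: the limit of > 22000 nM in this assay, at which 4 of the 4 values shown sit.

The compounds shown leave open whether swapping phenyl for methoxy, or changing the core, alters cytotoxicity at all in this assay.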